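Ring Directly on the Nitrogen: Compound 4 Expected

The source may hold more compounds than are shown below. What is called first, only, known or untested is meant among the compounds shown, and "the series" means these compounds.

Compound 1, `CC(C)CCN(C1=NCCN1)c1c(Br)cccc1Br`, was measured in a physicochemical assay for acid dissociation, where compound 1 gives 10.9. Two neighbours share its core. Compound 2, `C=CCCN(C1=NCCN1)c1c(Br)cccc1Br`, gives 11.2 in this assay, and compound 3, `Brc1cccc(Br)c1N(CC1CCCC1)C1=NCCN1`, gives 10.9. Across these three the differences stay inside the scatter: a number 0.30 log units higher from compound 1 to compound 2 (within the scatter), no change at the digits printed from compound 1 to compound 3 (within the scatter), and a number 0.30 log units lower from compound 2 to compound 3 (within the scatter). Compound 1 therefore sits level with compound 3, its nearest neighbour, while compound 2 is its furthest, and even that gap is within the scatter.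

Compound 4, `Brc1cccc(Br)c1N(C1=NCCN1)C1CCCC1`, has not been measured. Its difference from compound 1 is cyclopentyl in place of isopentyl on a nitrogen on an aromatic ring: what leaves is isopentyl, what enters is cyclopentyl, and the place is a nitrogen on an aromatic ring. The step from compound 1 to compound 3 also brings in cyclopentyl and is the closest guide; it was no change at the digits printed from compound 1 to compound 3 (within the scatter). The step from compound 2 to compound 3 was a number 0.30 log units lower from compound 2 to compound 3 (within the scatter). Within the data shown here, no step among the three exchanges the group sitting directly on the nitrogen, so the guide is imperfect. Still, nothing in the data points to a shift beyond the scatter, and the expected step is no change at the digits printed from compound 1 to compound 4 (within the scatter). Compound 4 is therefore estimated at 10.9, with a range from 10.4 to 11.4.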

Compound 4, acid dissociation constant: 11.2
Compound 4: the middle estimate sits 0.30 log units below what was measured; the range from low to high includes it.
By their numbers in this assay, from the lowest: compounds 1, 3, 2 and 4 (each within the scatter of the next).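

With compound 4, a ring stands directly on the nitrogen on an aromatic ring for the first time among these compounds. In this assay, putting cyclopentyl in place of isopentyl at this place gives a number 0.30 log units higher from compound 1 to compound 4 (within the scatter), while the comparison with the cyclopentylmethyl compound gives a number 0.30 log units higher from compound 3 to compound 4 (within the scatter) and the comparison with the but-3-en-1-yl compound gives no change at the digits printed from compound 2 to compound 4 (within the scatter), so neither the ring on the nitrogen nor the open chains separate the four compounds beyond the scatter. Nothing available bears on why the readings fall as they do.

The compounds shown leave open whether a group on this nitrogen that carries an amine or a carboxylic acid, or a much longer chain, would also stay within the scatter of these four compounds in this assay. Going by these compounds, it also remains open whether a ring of another size placed directly on the nitrogen, such as cyclopropyl or cyclohexyl, would read like cyclopentyl, since the only ring attached there so far has five members.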